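Removing one carbon from the amine substituent of compound 1

A few compounds are considered here, and "the series" means these few. Any claim that something is new, unique, unknown or untested is made for them only; others in the source may bear on it.

Compound 1: `CC(CNCC1CC1)Oc1cccc2ccc(N)nc12` — 80 nM
Compound 2: `CC(CNCC1CCCC1)Oc1cccc2ccc(N)nc12` — 100 nM

In an assay on cells with melanin-concentrating hormone receptor 1 (Homo sapiens) as the target, read by radioligand binding (on this read-out lower numbers stand for stronger inhibition and higher numbers for weaker inhibition), compound 1 shows the lower of the two numbers, though the step of a 1.3-fold higher number from compound 1 to compound 2 (0.10 log units; within the scatter) lies within the scatter. Compound 3 `CC(CNC1CC1)Oc1cccc2ccc(N)nc12` differs from compound 1 by cyclopropyl in place of cyclopropylmethyl on an amine nitrogen. Among the compounds with values here, no measured step covers this change; the one step available, a 1.3-fold higher number from compound 1 to compound 2 (0.10 log units; within the scatter), concerns the ring on the saturated chain carbon and was within the scatter. For compound 3 a step of a 1.5-fold higher number from compound 1 to compound 3 (0.18 log units; within the scatter) is therefore expected, with no clear direction beyond the scatter. Compound 3 is estimated at 120 nM, with a range from 40 nM to 400 nM.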

Compound 3, half-maximal inhibitory concentration: 50 nM
For compound 3 the middle estimate is 2.4-fold (0.38 log units) above the measured one, and the stated range covers the measured number.
By their numbers in this assay, from the lowest: compounds 3, 1 and 2 (each within the scatter of the next).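

In this assay, setting cyclopropyl directly on the amine nitrogen in place of cyclopropylmethyl gives a step that stays within the scatter (a 1.6-fold lower number from compound 1 to compound 3 (0.20 log units; within the scatter)), and so does the replacement of cyclopentylmethyl (a 2.0-fold lower number from compound 2 to compound 3 (0.30 log units; within the scatter)). Across these three compounds, the position therefore accepts removal of the carbon that links the ring to the nitrogen without a change beyond the scatter. No evidence is available to explain this result. Still open, going by these compounds, is whether a phenyl ring or a longer chain on this amine nitrogen would keep the number within the scatter.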